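Extending the nitrogen substituent of compound 2

The source may report more compounds than this note shows. Statements on the series, on what has been measured and on what is new or still open speak of the compounds shown alone.

Measured compounds:
Compound 1 `O=c1c2ccccc2c(-c2cccnc2)nn1C1CCCC1` — 2750 nM
Compound 2 `CC(=O)Cn1nc(-c2cccnc2)c2ccccc2c1=O` — 40700 nM

In a functional assay (trachea) with Cavia porcellus as the target (on this read-out higher numbers stand for weaker inhibition and lower numbers for stronger inhibition), compound 2 gives the highest of the two numbers; the nearest is compound 1, and the change was a 15-fold higher number from compound 1 to compound 2 (1.17 log units; beyond the scatter). Compound 3 `CC(C)NC(=O)CCCn1nc(-c2cccnc2)c2ccccc2c1=O` differs from compound 2 by 2-(isopropylcarbamoyl)ethyl in place of acetyl on a saturated chain carbon bound to an aromatic nitrogen. For the measured compounds named here, only that one step touches the group on the aromatic nitrogen, and it was large. Because a 15-fold higher number from compound 1 to compound 2 (1.17 log units; beyond the scatter) showed how much this position can move the number, a step of moderate size toward lower numbers is expected for compound 3, a 2.7-fold lower number from compound 2 to compound 3 (0.43 log units; beyond the scatter). Compound 3 is therefore estimated at 15000 nM, ranging from 4000 nM to 60000 nM.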

Compound 3, half-maximal inhibitory concentration: 64600 nM
Beside the measured number, compound 3's estimate is 4.3-fold (0.63 log units) below it, outside the stated range (above it).
By their numbers in this assay, from the lowest: compound 1; then compounds 2 and 3 (each within the scatter of the next).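

In this assay, putting 2-(isopropylcarbamoyl)ethyl in place of acetyl on a saturated chain carbon bound to an aromatic nitrogen gives a 1.6-fold higher number from compound 2 to compound 3 (0.20 log units; within the scatter) and so no real separation. The change enters a longer group with a hydrogen-bond donor, yet unlike the earlier swap of cyclopentyl, it leaves the read-out within the scatter. No measurement offered here explains this result.

On these data alone, whether an amine or a carboxylic acid on that chain carbon would produce a step beyond the scatter remains open. So does whether a cyclohexyl group on the aromatic nitrogen would keep the number near that of compound 1.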